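A few compounds are considered here, and "the series" means these few. Any claim that something is new, unique, unknown or untested is made for them only; others in the source may bear on it.

Compound 1 `CCCNC(=O)c1ccc2c(ccn2-c2ncc3c(n2)N(c2ccn(C)n2)C(CC)C(=O)N3C)c1`: 207 nM
Compound 2 `CCNC(=O)c1ccc2c(ccn2-c2ncc3c(n2)N(c2ccn(C)n2)C(CC)C(=O)N3C)c1`: 243 nM

For the measured compounds named here, in an assay for inhibition of serine/threonine-protein kinase PLK2 (Homo sapiens), read by FRET and Z'-LYTE, with a stated time of 1 h (a lower number here means a stronger inhibitor, a higher number a weaker inhibitor), compound 2 gives 243 nM, and compound 1 gives 207 nM as the only comparison available; the step of a 1.2-fold higher number from compound 1 to compound 2 (0.07 log units; within the scatter) is within the scatter, so the two stand together. Compound 3 `CCC1C(=O)N(C)c2cnc(-n3ccc4cc(C(=O)NC5CCCC5)ccc43)nc2N1c1ccn(C)n1` differs from compound 2 by cyclopentyl in place of ethyl on an amide-type nitrogen. Going by the values given here, the single measured step also changed the substituent on that amide-type nitrogen and lay within the scatter, so no move beyond the scatter is expected from compound 2 to compound 3, an estimated 1.3-fold lower number from compound 2 to compound 3 (0.11 log units; within the scatter). Compound 3 is therefore expected at 190 nM, within a range of 70 nM to 500 nM.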

Compound 3, half-maximal inhibitory concentration: 90.9 nM
Compound 3: middle estimate off by 2.1-fold (0.32 log units), on the high side; measured number inside the range.
By their numbers in this assay, from the lowest: compound 3; then compounds 1 and 2 (each within the scatter of the next).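

On the amide-type nitrogen, the step from propyl to ethyl had stayed within the scatter, but cyclopentyl shifts the number in this assay beyond it, with a 2.7-fold lower number from compound 2 to compound 3 (0.43 log units; beyond the scatter) and a 2.3-fold lower number from compound 1 to compound 3 (0.36 log units; beyond the scatter). This position therefore responds to its substituent, although both shifts are modest. No available evidence accounts for the shift.

As far as these compounds go, whether the shift follows the ring itself or the larger count of carbons remains open. A pentyl chain, a cyclohexyl ring or a phenyl ring on the same nitrogen would help separate the two.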